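A few compounds are considered here, and "the series" means these few. Any claim that something is new, unique, unknown or untested is made for them only; others in the source may bear on it.

Measured so far in a functional assay on SK-MEL cells (Homo sapiens) for cytotoxicity, read by MTT assay, with a stated time of 6 days; on this read-out lower numbers stand for an effect already at smaller amounts and higher numbers for an effect only at larger amounts of compound:

Compound 1, `COC(=O)c1c(-c2ccc(OC)cc2)oc2ccccc2c1=O`: > 25 ug/mL
Compound 2, `COC(=O)c1c(-c2ccc([N+](=O)[O-])cc2)oc2ccccc2c1=O`: > 25 ug/mL
Compound 3, `COC(=O)c1c(-c2ccc(O)cc2)oc2ccccc2c1=O`: > 25 ug/mL

The value of compound 1 is a limit of this assay, not a number. The value of compound 2 is likewise a limit. The value of compound 3 is likewise a limit. All three sit at the limit of > 25 ug/mL in this assay, at which 3 of the 3 values shown sit, so none of the three is separated from the others on this read-out.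

Compound 2 differs from compound 1 in its core by nitro in place of methoxy on an aromatic carbon. Compound 3 is reached from compound 1 by hydrogen in place of methyl on an oxygen on an aromatic ring; the size of this step is a step that the two limits leave unreadable from compound 1 to compound 3. Between compound 1 and compound 2 the step is a step that the two limits leave unreadable from compound 1 to compound 2, and between compound 2 and compound 3 it is a step that the two limits leave unreadable from compound 2 to compound 3.

Compound 4, `O=C(O)c1c(-c2ccc([N+](=O)[O-])cc2)oc2ccccc2c1=O`, has not yet been measured in this assay. It is reached from compound 2 by hydrogen in place of methyl on an oxygen next to a carbonyl group. For the measured compounds named here, this is the same kind of change as the one from compound 1 to compound 3, but not the same: there the methyl left an oxygen on an aromatic ring whose other neighbour is an aromatic carbon, here it leaves an oxygen next to a carbonyl group whose other neighbour is a carbonyl carbon.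

Since the earlier step of this kind could not be read from the two limits of compound 1 and compound 3, the step from compound 2 to compound 4 is expected to be a step that the limit leaves unreadable from compound 2 to compound 4, with little confidence in either direction. Compound 4 is therefore expected to give about 30 ug/mL in this assay, somewhere between 8 ug/mL and 120 ug/mL, and most likely again only a limit.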

Compound 4, concentration for half-maximal effect: > 25 ug/mL
Compound 4 ended at the assay's limit; the forecaster's own chance of this, stated with the estimate: 80%; the middle value does not contradict the limit.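

In this assay compound 4 gives > 25 ug/mL, which is a limit of the assay and not a number. Compound 2 stands at the same limit, so the change from methoxycarbonyl to carboxy between these two compounds cannot be read, and no new step emerges: the limit of > 25 ug/mL in this assay, at which 4 of the 4 values shown sit.

Compound 1, compound 2, compound 3 and compound 4 leave open at what concentration each would reach its half-maximal effect, and so whether any of these changes matters in this assay.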